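Allyl Disulfide to Butyl Disulfide: Half-Life Outlook

The source may report more compounds than this note shows. Statements on the series, on what has been measured and on what is new or still open speak of the compounds shown alone.

Compound 1 `Cc1cn([C@H]2C[C@H](SSc3ccccc3[N+](=O)[O-])[C@@H](CO)O2)c(=O)[nH]c1=O` and compound 2 `C=CCSS[C@H]1C[C@H](n2cc(C)c(=O)[nH]c2=O)O[C@@H]1CO` share one core and differ only in the group carried on a sulfur. In a physicochemical assay for pharmacokinetics, at pH 7.2 (on this read-out higher numbers stand for a longer-lived compound and lower numbers for a shorter-lived compound), compound 1 gives only a limit, < 0.0834 h. Compound 2 likewise gives only a limit, < 0.0834 h. The step that the two limits leave unreadable from compound 1 to compound 2 therefore cannot be read, since both values sit at the same limit (the limit of < 0.0834 h in this assay, at which 2 of the 2 values shown sit). Compound 3 `CCCCSS[C@H]1C[C@H](n2cc(C)c(=O)[nH]c2=O)O[C@@H]1CO` carries propyl in place of vinyl on a saturated chain carbon bound to a sulfur. Among the measured compounds shown here, no measured step shows what such a change does, so the expected step that the limit leaves unreadable from compound 2 to compound 3 is set near zero. Compound 3 is therefore expected at about 0.06 h in this assay, within 0.02 h to 0.25 h.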

Compound 3, half-life: < 0.0834 h
Compound 3 ended at the assay's limit; the forecaster's own chance of this, stated with the estimate: 70%; the middle value is on the limit's open side.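

No step can be read among compound 1, compound 2 and compound 3, as each gives only a limit in this assay: the limit of < 0.0834 h in this assay, at which 3 of the 3 values shown sit.

As far as these compounds go, whether the group carried on the sulfur changes the half-life at all stays open.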